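The compounds below may be only part of what the source reports. "The series", "measured", "known", "first", "only" and "open" are said of these compounds alone.

Measured so far in a functional assay on the whole organism with Rattus norvegicus as the target; a higher number here means that more compound is needed for the effect, a lower number that less compound is needed:
- compound 1 `Oc1nc(-c2ccccc2)ncc1-c1nn[nH]n1`: 100 mg/kg
- compound 2 `CC(C)Oc1ccccc1-c1ncc(-c2nn[nH]n2)c(O)n1`: 0.04 mg/kg
- compound 3 `CCCCCOc1ccccc1-c1ncc(-c2nn[nH]n2)c(O)n1`: 0.4 mg/kg

Compound 3 holds the second highest of the three numbers. Compound 2 is its nearest neighbour and compound 1 lies furthest away.

Next in line is compound 4 `Oc1nc(-c2ccccc2OCC2CC2)ncc1-c1nn[nH]n1`, not yet measured. The change is cyclopropyl in place of butyl on a saturated chain carbon bound to an oxygen on an aromatic ring, which can also be read as pentyloxy to cyclopropylmethoxy.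

Two steps show what an alkoxy group on the aromatic ring was worth: a 2500-fold lower number from compound 1 to compound 2 (3.40 log units; beyond the scatter), and a 250-fold lower number from compound 1 to compound 3 (2.40 log units; beyond the scatter). Both are large, but they say little about the present swap, which leaves the oxygen in place. Among the measured compounds shown here, the closest evidence is a 10-fold higher number from compound 2 to compound 3 (1.00 log units; beyond the scatter), a modest step and the only measured change of the group on that oxygen. For the measured compounds named here, no measured compound carries a ring there, so this single step is only a rough guide.

A modest move toward compound 2 is therefore expected in this assay, with the estimated step being a 4.0-fold lower number from compound 3 to compound 4 (0.60 log units; beyond the scatter). The uncertainty is wide, and a result near compound 3 would not be surprising.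

For compound 4 the estimate is 0.1 mg/kg, with an expected range of 0.02 mg/kg to 0.5 mg/kg.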

Compound 4, dose for 50% inhibition: 0.07 mg/kg
The estimate for compound 4 lay 1.4-fold (0.15 log units) above the measured number; measured number inside the range.
By their numbers in this assay, from the lowest: compounds 2 and 4 (each within the scatter of the next); then compound 3; then compound 1.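

Within this assay, the swap of butyl for cyclopropyl brings the first ring onto the saturated chain on that oxygen, and it gives a 5.7-fold lower number from compound 3 to compound 4 (0.76 log units; beyond the scatter) as a modest step beyond the scatter. The chain group can therefore carry a three-membered ring without the higher number seen with pentyl, as the printed a 1.8-fold higher number from compound 2 to compound 4 (0.24 log units; within the scatter) leaves cyclopropylmethyl and isopropyl within the scatter of each other and thus not separable in this assay. The value of an alkoxy group over hydrogen on the aromatic carbon now also holds for a third group, with a 1400-fold lower number from compound 1 to compound 4 (3.15 log units; beyond the scatter) as a large step of the same order as those seen for isopropoxy and pentyloxy.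

The compounds shown offer no measured information that accounts for any of these steps. Still open, from the compounds shown here alone, is how a group such as methoxy, cyclobutylmethyl or cyclohexylmethyl would read on that oxygen, and whether a chain ending in an amine or a carboxylic acid would stay near compound 2 and compound 4 or fall back toward compound 3.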